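Ortho Methyl on the Phenyl Ring of Compound 1

The source may hold more compounds than are shown below. What is called first, only, known or untested is meant among the compounds shown, and "the series" means these compounds.

Compound 1 `O=c1[nH]nc2n(c1=O)CCN2c1ccccc1` is the reference point of this small set. In an ADME assay on Vero cells (Chlorocebus sabaeus) for cytotoxicity, with a stated time of 72 h, tested at 50 ug/mL (a higher number here means a stronger effect of the compound at the concentration tested, a lower number a weaker effect), compound 1 gives 30%, the highest of the three numbers recorded. Compound 3 `Cc1cccc(N2CCN/C2=N\N)c1C`, built on a different core, gives 14% in this assay, and compound 2 `Cc1ccc(N2CCn3c2n[nH]c(=O)c3=O)cc1` gives 0%. Among the measured compounds shown here, the one direct step that has been measured, a number 30 percentage points lower from compound 1 to compound 2 (beyond the scatter), is a methyl in place of hydrogen on an aromatic carbon.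

Compound 4 `Cc1ccccc1N1CCn2c1n[nH]c(=O)c2=O` differs from compound 1 by methyl in place of hydrogen on an aromatic carbon, the new group sitting on an aromatic carbon of a six-membered aromatic ring of carbon only, ortho to a large group. The step from compound 1 to compound 2 is the only one that bears on this change, and it ran downward by a modest but clear margin. The same kind of change is therefore expected to lower the number again, though the place of the methyl differs and the size is uncertain. Compound 4 is estimated at 12%, between 0% and 35%, an expected step of a number 18 percentage points lower from compound 1 to compound 4 (beyond the scatter).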

Compound 4, a percentage reported as inhibition, at one concentration (the size of the read-out at that concentration, not a potency): 0%
Compound 4: middle estimate off by 12 percentage points, on the high side; the range from low to high includes it.
By their numbers in this assay, from the lowest: compounds 2 and 4 (each within the scatter of the next); then compound 3; then compound 1.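

In this assay the methyl in place of hydrogen, ortho to a large group, gives a number 30 percentage points lower from compound 1 to compound 4 (beyond the scatter), which shows that the fall seen with compound 2 is not confined to a single placement of the methyl on the six-membered aromatic ring. Compound 2 gives 0% and compound 4 gives 0%, so the two placements cannot be told apart in this read-out, and a zero leaves no room to see any further fall. Nothing shown here accounts for the loss of effect.

The compounds shown leave open whether a larger or different group ortho to a large group, such as a chlorine, a methoxy group or an amine, would lower the number as methyl does. They also leave open whether a carboxylic acid on that ring would keep the number of compound 1 at 30%.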